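Working notes on a three-compound series

The compounds below may be only part of what the source reports. "The series", "measured", "known", "first", "only" and "open" are said of these compounds alone.

Compound 1 `CC(C(=O)N1CCN(c2ccccc2)CC1)N1C(=O)CCC1=O` opens the series. In a functional assay on the whole organism (strain Swiss) with Mus musculus as the target, in the maximal electroshock model, with a stated time of 2 h, at a dose of 100 mg/kg by the intraperitoneal route (a lower number here means a weaker effect, a higher number a stronger effect of the compound at the dose given), compound 1 gives 0%. Compound 2 `CCC(C(=O)N1CCN(c2cccc(C)c2)CC1)N1C(=O)CCC1=O` follows, and in this assay compound 2 gives 0%. On these numbers compound 2 stands level with compound 1 at the digits shown; its nearest neighbour is compound 1, and the two lie within the usual scatter of each other, so neither can be called the stronger.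

Compound 3 `CCC(C(=O)N1CCN(c2ccccc2)CC1)N1C(=O)CCC1=O` has not yet been measured. It differs from compound 2 by hydrogen in place of methyl on an aromatic carbon. Going by the values given here, no step between measured compounds is at hand, so the size of this step can only be judged from the two measured values, both of which show no measurable effect. The step from compound 2 to compound 3 is expected to be no change at the digits printed from compound 2 to compound 3 (within the scatter), none beyond the scatter. For compound 3 in this assay the estimate is 0%, with a range from 0% to 10%.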

Compound 3, a percentage reported as activity, at one dose (the size of the read-out at that dose, not a potency): 0%
Compound 3: middle estimate and measured number agree at the digits printed, within the range that was stated.
By their numbers in this assay, from the lowest: compounds 1, 2 and 3 (each within the scatter of the next).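

In this assay, the change from 3-methylphenyl to phenyl gives no change at the digits printed from compound 2 to compound 3 (within the scatter), and methyl in place of hydrogen on the saturated chain carbon gives no change at the digits printed from compound 1 to compound 3 (within the scatter). Neither change, one on the aromatic carbon and one on the chain, brings out a response in this read-out at the dose given, so the series now has a step at each of the two places and neither step shows an effect. No measurement bearing on the reason for this flat result is available.

Since a response is absent on both sides of each step, these compounds cannot show how much either position matters in a compound that does respond. As far as these compounds go, whether a chlorine or a methoxy group on that aromatic carbon, or a longer chain on the saturated chain carbon, would produce a response remains open.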